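The compounds below may be only part of what the source reports. "The series", "measured", "known", "first", "only" and "open" are said of these compounds alone.

Compound 1, `N#C[C@]1(O)[C@H](O)[C@@H](CO)O[C@@H](n2ccc(O)nc2=O)[C@@H]1O`, and compound 2, `N#C[C@H]1[C@@H](O)[C@H](n2cc(F)c(O)nc2=O)O[C@H](CO)[C@H]1O`, were both tested in a functional assay on CCRF-CEM cells (Homo sapiens); a higher number here means a weaker inhibitor, a lower number a stronger inhibitor. In this assay compound 1 gives > 500000 nM, which is a limit of the assay and not a measured number. In this assay compound 2 gives > 500000 nM, again a limit rather than a number. Compound 2 thus stands at the same limit as compound 1, as the limit of > 500000 nM in this assay, at which 2 of the 2 values shown sit, shows. Compound 3, `N#C[C@H]1[C@@H](O)[C@H](n2ccc(O)nc2=O)O[C@H](CO)[C@H]1O`, is still to be measured in this assay. It differs from compound 2 by hydrogen in place of fluoro on an aromatic carbon. For the measured compounds named here, no step between measured compounds is available, so the only footing is that compound 1 and compound 2 both sit at the limit. The step expected in this assay is a number no higher from compound 2 to compound 3 (the limit leaves the size open), no change beyond the scatter. For compound 3 the estimate is therefore 500000 nM, with a range from 100000 nM to 2000000 nM, most likely reported once more only as a limit.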

Compound 3, half-maximal inhibitory concentration: > 500000 nM
Compound 3: only a limit was reported; the forecaster's own chance of this, stated with the estimate: 85%; the middle value lies on the limit itself.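

In this assay compound 3 gives > 500000 nM, a limit of the assay and not a number. Compound 2 stands at the same limit, so no step can be read between compound 2 and compound 3. The compounds shown leave open how strongly each inhibits and whether hydrogen in place of fluoro changes this at all.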